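Compound 2 and its N-hydrogen counterpart

This account rests on a few compounds, and the source may have more. Where it says the series, first, only, none or still open, it means among the compounds named here.

compound 1 `Cn1ccc2c(Oc3ccc(NC(=O)c4cc5cccnc5n(-c5ccc(C(F)(F)F)c(Cl)c5)c4=O)cc3F)ncnc21`: 156000 nM
compound 2 `Cn1ccc2c(Oc3ccc(NC(=O)c4cc5cccnc5n(-c5ccc(C(F)(F)F)cc5Cl)c4=O)cc3F)ncnc21`: 170000 nM

In a functional assay on HeLa cells (Homo sapiens) for cytotoxicity, read by MTT assay, with a stated time of 72 h (on this read-out lower numbers stand for stronger inhibition and higher numbers for weaker inhibition), compound 2 gives 170000 nM, which lies within the scatter of compound 1. Compound 3 `O=C(Nc1ccc(Oc2ncnc3[nH]ccc23)c(F)c1)c1cc2cccnc2n(-c2ccc(C(F)(F)F)cc2Cl)c1=O` is related to compound 2 by hydrogen in place of methyl on an aromatic nitrogen. Among the measured compounds shown here, the only measured step, a 1.1-fold higher number from compound 1 to compound 2 (0.04 log units; within the scatter), concerns a different group and does not test this change. No step beyond the scatter can therefore be firmly expected, though the uncertainty is wide. The expected step is a 1.4-fold lower number from compound 2 to compound 3 (0.15 log units; within the scatter). For compound 3 the estimated value is 120000 nM, with an expected range of 25000 nM to 250000 nM.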

Compound 3, half-maximal inhibitory concentration: 96800 nM
Estimate against measurement, compound 3: 1.2-fold (0.09 log units) above; the measured number falls inside the stated range.
By their numbers in this assay, from the lowest: compounds 3, 1 and 2 (each within the scatter of the next).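

In this assay, hydrogen in place of methyl on the aromatic nitrogen of the five-membered ring gives a 1.8-fold lower number from compound 2 to compound 3 (0.24 log units; within the scatter) and so leaves the read-out within the scatter. Among the compounds shown here, this is the first reading at this nitrogen, since the earlier step concerned only the chloro placement on the phenyl group. Nothing available accounts for this result.

On these data alone, it remains open whether an ethyl group or a longer chain ending in an amine on this nitrogen would also stay within the scatter. As far as these compounds go, the same replacement alongside 3-chloro-4-(trifluoromethyl)phenyl also remains open.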